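A few compounds are considered here, and "the series" means these few. Any claim that something is new, unique, unknown or untested is made for them only; others in the source may bear on it.

Measured compounds:
Compound 1 `CCCOCCn1c(N2CCCN(C)CC2)nc2ccccc21` — 16 nM
Compound 2 `CCCCCCn1c(N2CCN(C)CC2)nc2ccccc21` — 26 nM
Compound 3 `CCCCCN1CCCN(c2nc3ccccc3n2CCOCC)CC1` — 7.4 nM

These three share one core and were measured in a functional assay on ileum for inhibition of histamine H1 receptor (Cavia porcellus); a lower number here means a stronger inhibitor, a higher number a weaker inhibitor. Compound 2 gives the highest of the three numbers. Its nearest neighbour is compound 1, whose value of 16 nM sits within the usual scatter of that of compound 2, so the two cannot be told apart. Compound 3, at 7.4 nM, gives a number clearly lower than that of compound 2, a gap that lies beyond the scatter. No pair of these compounds differs in only one place, so no single structural step can be read from them.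

Compound 4 `CN1CCN(c2nc3ccccc3n2CCOCCO)CC1` has not yet been measured. Set against compound 2 it differs as follows:
2-hydroxyethoxy in place of butyl on a saturated chain carbon, two bonds along the chain from an aromatic nitrogen

Going by the values given here, nothing among the measured compounds shows the effect of this change, so the expectation rests on the change itself and on the value of compound 2. The step of a 3.5-fold higher number from compound 2 to compound 4 (0.54 log units; beyond the scatter) is expected to run upward, towards a weaker inhibitor, and to exceed the scatter. Compound 4 is therefore estimated at 90 nM in this assay, with a range from 25 nM to 320 nM.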

Compound 4, half-maximal inhibitory concentration: 42 nM
The estimate for compound 4 lay 2.1-fold (0.33 log units) above the measured number, within the range that was stated.
By their numbers in this assay, from the lowest: compound 3; then compounds 1, 2 and 4 (each within the scatter of the next, the first and the last beyond it).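

In this assay, going by these compounds alone, the exchange of butyl for 2-hydroxyethoxy on a saturated chain carbon, two bonds along the chain from an aromatic nitrogen, provides the first comparison of compounds that differ in one place: a 1.6-fold higher number from compound 2 to compound 4 (0.21 log units; within the scatter). This step lies within the scatter, so compound 2 and compound 4 cannot be told apart in this assay. Thus, at this position, the all-carbon butyl can be replaced by a group of the same heavy-atom count that carries oxygen, a hydrogen-bond donor and hydrogen-bond acceptors without a readable change in the number, and no evidence is available to account for this.

On these data alone, compound 4 carries the chain oxygen and the terminal hydroxyl together, so their separate contributions remain open, and a 2-methoxyethoxy group, a terminal amine or a carboxylic acid at this position would give further points of comparison. As far as these compounds go, it also remains open whether the same exchange would read alike on the amine portion of compound 1 or compound 3, or with a longer chain in place of 2-hydroxyethoxy.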